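The source may report more compounds than this note shows. Statements on the series, on what has been measured and on what is new or still open speak of the compounds shown alone.

Measured so far:
compound 1, `COc1cc(-c2nnc3n2NC(c2ccco2)C(C(=O)c2ccc(Cl)cc2)S3)cc(OC)c1OC`: 67800 nM
compound 2, `COc1cc(-c2nnc3n2NC(c2ccco2)C(C(=O)c2ccc(F)cc2)S3)cc(OC)c1OC`: 27700 nM
compound 3, `COc1cc(-c2nnc3n2NC(c2ccco2)C(C(=O)C2CC2)S3)cc(OC)c1OC`: 95200 nM

In a functional assay on PC-3 cells (Homo sapiens) for cytotoxicity, read by MTT assay, with a stated time of 48 h (on this read-out lower numbers stand for stronger inhibition and higher numbers for weaker inhibition), compound 3 stands at the highest of the three numbers. Its nearest neighbour is compound 1, and a 1.4-fold higher number from compound 1 to compound 3 (0.15 log units; within the scatter) lies within the scatter, so the two cannot be set in order. Its furthest neighbour is compound 2, and a 3.4-fold higher number from compound 2 to compound 3 (0.54 log units; beyond the scatter) lies beyond the scatter. Among the aryl ketones, a 2.4-fold lower number from compound 1 to compound 2 (0.39 log units; beyond the scatter).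

Compound 4, `COc1cc(-c2nnc3n2NC(c2ccco2)C(C(=O)c2ccc(C)cc2)S3)cc(OC)c1OC`, differs from compound 3 in one place: 4-methylphenyl in place of cyclopropyl on a carbonyl carbon. Among the compounds with values here, the steps that bear on this change are the two that exchange cyclopropyl for a para-substituted phenyl on the same carbonyl carbon, one within the scatter and one modest, both running toward lower numbers when the phenyl enters. The 4-methylphenyl of compound 4 is not among the measured groups, so the expectation is set between those two steps. Compound 4 is therefore expected to show a 2.1-fold lower number from compound 3 to compound 4 (0.33 log units; beyond the scatter), a modest move toward a lower number. The estimate for compound 4 is 45000 nM, with a range from 15000 nM to 120000 nM.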

Compound 4, half-maximal inhibitory concentration: 7500 nM
Compound 4: the middle estimate sits 6.0-fold (0.78 log units) above what was measured, outside the stated range (below it).
By their numbers in this assay, from the lowest: compound 4; then compound 2; then compounds 1 and 3 (each within the scatter of the next).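

Within the data shown here, in the study's cytotoxicity read-out (this assay), the group on the carbonyl carbon proves able to shift the number far more than the earlier compounds suggested, with 4-methylphenyl replacing cyclopropyl giving a large step (a 13-fold lower number from compound 3 to compound 4 (1.10 log units; beyond the scatter)). The phenyl ring alone does not account for this, since compound 1 stays within the scatter of compound 3, while methyl outdoes both fluoro (a 3.7-fold lower number from compound 2 to compound 4 (0.57 log units; beyond the scatter)) and chloro (a 9.0-fold lower number from compound 1 to compound 4 (0.96 log units; beyond the scatter)) on the same aromatic carbon. Compounds 1, 2 and 4 therefore stand apart from one another, each beyond the scatter, and what the ring carries decides the outcome.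

Going by these compounds, whether an unsubstituted phenyl, a methoxy, an ethyl or a longer chain on that ring would hold so low a number remains open. Nothing at hand explains why the methyl compound parts so far from the two halogen compounds.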